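This account rests on a few compounds, and the source may have more. Where it says the series, first, only, none or still open, it means among the compounds named here.

In a functional assay on HL-60 cells (Homo sapiens) for cytotoxicity, read by WST assay, with a stated time of 48 h (on this read-out lower numbers stand for stronger inhibition and higher numbers for weaker inhibition), compound 2 `COc1ccc(/C=C/C[C@H]2C[C@@H]([C@@H](O)c3ccccc3)CO[C@@H]2c2ccccc2)cc1` gives 9010 nM, the lowest of the two numbers shown, yet it lies within the scatter of compound 1 `Oc1ccccc1/C=C/C[C@H]1C[C@@H]([C@@H](O)c2ccccc2)CO[C@@H]1c1ccccc1`, which in this assay gives 10800 nM, so no order can be read from the pair. Within the data shown here, the one measured step, a 1.2-fold lower number from compound 1 to compound 2 (0.08 log units; within the scatter), was 4-methoxyphenyl in place of 2-hydroxyphenyl on a double-bonded chain carbon bound to a double-bonded chain carbon. Compound 3 `O[C@@H](c1ccccc1)[C@H]1CO[C@H](c2ccccc2)[C@@H](C/C=C/C2CCCCC2)C1` has not yet been measured in this assay. It differs from compound 2 by cyclohexyl in place of 4-methoxyphenyl on a double-bonded chain carbon bound to a double-bonded chain carbon. Among the measured compounds shown here, only the step from compound 1 to compound 2 bears on this change, and it touched the same place: exchanging one six-membered aromatic ring for another left the number within the scatter. For the measured compounds named here, no measured step exchanges an aromatic ring for a non-aromatic ring, so the expectation rests on that single step alone. Compound 3 is therefore expected to show a step of a 1.0-fold lower number from compound 2 to compound 3 (0.00 log units; within the scatter), none beyond the scatter. The estimate for compound 3 in this assay is 9000 nM, within a range from 3500 nM to 25000 nM.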

Compound 3, half-maximal inhibitory concentration: 6260 nM
Compound 3: middle estimate off by 1.4-fold (0.16 log units), on the high side; low and high end bracket the measured number.
By their numbers in this assay, from the lowest: compounds 3, 2 and 1 (each within the scatter of the next).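

In this assay, cyclohexyl in place of 4-methoxyphenyl on a double-bonded chain carbon bound to a double-bonded chain carbon gave a 1.4-fold lower number from compound 2 to compound 3 (0.16 log units; within the scatter), and the same group in place of 2-hydroxyphenyl gave a 1.7-fold lower number from compound 1 to compound 3 (0.24 log units; within the scatter). The earlier pair had shown only one six-membered aromatic ring exchanged for another, whereas these steps show that a non-aromatic ring of carbon only, carrying neither methoxy nor hydroxy, also leaves the number within the scatter at this place. Nothing available accounts for this lack of a readable difference among the three groups.

From the compounds shown here alone, with compound 3 at 6260 nM, all three compounds remain within the scatter of one another, so it stays open whether any group at this place can move the number beyond the scatter. Going by these compounds, a basic amine such as a piperidinyl ring, a carboxylic acid on the phenyl ring, or an open alkyl chain in place of the ring could each test this, and the shared core, unchanged throughout, remains untested.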